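Swapping 4-ethylphenyl for 2,3-dimethoxyphenyl in the amide series

This account rests on a few compounds, and the source may have more. Where it says the series, first, only, none or still open, it means among the compounds named here.

Of the compounds shown here, three on the shared core have been measured in a functional assay on A2780 cells (Homo sapiens) for antiproliferative activity, read by resazurin assay, with a stated time of 72 h; a lower number here means a stronger inhibitor, a higher number a weaker inhibitor. Compound 1 `CN(Cc1ccccc1F)C(=O)c1cc2c(Cc3ccccc3)n[nH]c2cc1O` gives 1500 nM, compound 2 `CN(Cc1ccc(F)cc1)C(=O)c1cc2c(Cc3ccccc3)n[nH]c2cc1O` gives 4100 nM and compound 3 `CCc1ccc(CN(C)C(=O)c2cc3c(Cc4ccccc4)n[nH]c3cc2O)cc1` gives 9400 nM. Compound 3 therefore has the highest number of the three and is the weakest inhibitor so far.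

The next change leads to compound 4 `COc1cccc(CN(C)C(=O)c2cc3c(Cc4ccccc4)n[nH]c3cc2O)c1OC`, where 2,3-dimethoxyphenyl takes the place of 4-ethylphenyl on a saturated chain carbon bound to an amide-type nitrogen: 2,3-dimethoxyphenyl in place of 4-ethylphenyl on a saturated chain carbon bound to an amide-type nitrogen.

Three modest measured steps bear on this site. Ethyl in place of fluoro on an aromatic carbon gives a 2.3-fold higher number from compound 2 to compound 3 (0.36 log units; beyond the scatter). 4-Fluorophenyl in place of 2-fluorophenyl gives a 2.7-fold higher number from compound 1 to compound 2 (0.44 log units; beyond the scatter), and 4-ethylphenyl in place of 2-fluorophenyl gives a 6.3-fold higher number from compound 1 to compound 3 (0.80 log units; beyond the scatter). Among the compounds with values here, the lowest number belongs to compound 1 at 1500 nM, the only measured compound with a group at the 2-position of this phenyl. Within the data shown here, compound 4 also has one there, but no dimethoxy compound has been measured, so this is a weak guide.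

A modest move to a lower number is expected, with a 2.7-fold lower number from compound 3 to compound 4 (0.43 log units; beyond the scatter) as the estimated step. The estimate for compound 4 is 3500 nM, with an expected range of 1200 nM to 9500 nM.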

Compound 4, half-maximal inhibitory concentration: 4800 nM
The estimate for compound 4 lay 1.4-fold (0.14 log units) below the measured number, within the range that was stated.
By their numbers in this assay, from the lowest: compound 1; then compounds 2, 4 and 3 (each within the scatter of the next, the first and the last beyond it).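

In this assay, 2,3-dimethoxyphenyl on a saturated chain carbon bound to an amide-type nitrogen cannot be told apart from either 4-ethylphenyl, with a 2.0-fold lower number from compound 3 to compound 4 (0.29 log units; within the scatter), or 4-fluorophenyl, with a 1.2-fold higher number from compound 2 to compound 4 (0.07 log units; within the scatter). It does stay separate from 2-fluorophenyl, with a 3.2-fold higher number from compound 1 to compound 4 (0.51 log units; beyond the scatter), so compound 1 remains the strongest inhibitor of the four, and a ring substituted as in 2,3-dimethoxyphenyl does not match it. The compounds give no measured basis for explaining these numbers.

As far as these compounds go, it remains open whether the lower number of compound 1 belongs to fluoro specifically, which 2-chlorophenyl, 2-methoxyphenyl or plain phenyl at this site would help to separate, and whether the two methoxy groups of compound 4 act together or oppose each other, which 3-methoxyphenyl would help to show. A ring carrying an amine or a carboxylic acid, or a longer chain in place of the single saturated carbon, also lies outside what these four compounds can say about the position.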